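This account rests on a few compounds, and the source may have more. Where it says the series, first, only, none or still open, it means among the compounds named here.

Three compounds built on one shared core have been run through an ADME assay on microsomes from liver (Homo sapiens) for metabolic stability, read by LC-MS, using NADPH, with stated times of 5 min and 30 min, tested at 1 uM; on this read-out higher numbers stand for fast clearance and lower numbers for slow clearance. Compound 1, `CNC(=O)c1ccc(-c2cnc(NCc3c(F)ccc4c3CCO4)c3cn[nH]c(=O)c23)c(C)n1`, gives 23 mL.min-1.g-1 in this assay. Compound 2, `Cc1ncccc1-c1cnc(NCc2c(F)ccc3c2CCO3)c2nn(CC#N)c(=O)n12`, gives 151 mL.min-1.g-1 in this assay. Compound 3, `O=C1CC2(CC2)CN1c1cnc(NCc2c(F)ccc3c2CCO3)n2cnnc12`, returns only a limit in this assay, < 3 mL.min-1.g-1, so its true value is a boundary rather than a number. This boundary is the limit of < 3 mL.min-1.g-1 in this assay, at which 1 of the 3 values shown sits, and compound 3 is the one that rests there. Compound 4, `CN(C(=O)c1ccccc1)c1cnc(NCc2c(F)ccc3c2CCO3)n2cnnc12`, has not yet been tested in this assay. It differs from compound 3 in one place: a group of 10 heavy atoms (8 carbon, 1 nitrogen, 1 oxygen; one six-membered aromatic ring of carbon only) in place of a group of 8 heavy atoms (6 carbon, 1 nitrogen, 1 oxygen; one three-membered non-aromatic ring of carbon only, one five-membered non-aromatic ring with 1 hetero atom), on an aromatic carbon. Going by the values given here, no two measured compounds differ in a single place, so no measured step guides the expectation; the values of compound 1 and compound 2 show only that this core can land far apart in this assay. Compound 4 is estimated to give 15 mL.min-1.g-1 in this assay, most likely between 4 mL.min-1.g-1 and 50 mL.min-1.g-1. The expected step of an at least 5.0-fold higher number from compound 3 to compound 4 (0.69 log units; beyond the scatter) points toward faster clearance and may exceed the scatter, though a second limit remains possible.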

Compound 4, intrinsic clearance in microsomes: > 300 mL.min-1.g-1
Compound 4: only a limit was reported (the forecaster's own chance of this, stated with the estimate: 25%); middle value at least 20-fold (1.30 log units) away from the limit.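

In this assay this place on the shared core proves decisive: putting benzoyl(methyl)amino in place of the group with the three-membered and five-membered rings gives an at least 100-fold higher number from compound 3 to compound 4 (2.00 log units; beyond the scatter) from one change on an aromatic carbon. Compound 3 rests on a limit and not on a number: the limit of < 3 mL.min-1.g-1 in this assay, at which 1 of the 4 values shown sits.
Compound 4 rests on a limit at the opposite end, so the true gap may be wider still: the limit of > 300 mL.min-1.g-1 in this assay, at which 1 of the 4 values shown sits.

Which part of benzoyl(methyl)amino goes with this jump stays open, and no cause for it can be read from these compounds. A simpler amide such as acetyl(methyl)amino, or a benzoyl(methyl)amino carrying a carboxylic acid on its ring, would show whether a value can fall between the two limits at this place.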